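Moving a methyl group around the benzoyl ring

The source may report more compounds than this note shows. Statements on the series, on what has been measured and on what is new or still open speak of the compounds shown alone.

Of the compounds shown here, three sharing a core have been measured in an ADME assay on Li23 cells (Homo sapiens) for cytotoxicity, read by WST assay; a lower number here means that less compound is tolerated, a higher number that more compound is tolerated. Compound 1, `Cc1cc(C(O)(C(F)(F)F)C(F)(F)F)ccc1N(C)C(=O)c1ccccc1`, gives 9000 nM. Compound 2, `Cc1cc(N(C)C(=O)c2ccccc2)ccc1C(O)(C(F)(F)F)C(F)(F)F`, gives 87000 nM. Compound 3, `Cc1ccccc1C(=O)N(C)c1ccc(C(O)(C(F)(F)F)C(F)(F)F)cc1`, gives 38000 nM. On these numbers compound 3 stands second highest of the three: the nearest value is that of compound 2, which lies higher by more than the usual scatter, and the furthest is that of compound 1, which lies lower, again beyond the scatter. More compound 3 is therefore tolerated than compound 1, and less than compound 2.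

Compound 4, `Cc1ccc(C(=O)N(C)c2ccc(C(O)(C(F)(F)F)C(F)(F)F)cc2)cc1`, is built from the same atoms as compound 3, joined differently: 4-methylphenyl in place of 2-methylphenyl on a carbonyl carbon. The methyl group simply changes its place on the ring attached to the carbonyl, with no change in donors, acceptors or charge. Within the data shown here, no measured pair shows what such a shift does here, so nothing in the numbers points clearly up or down.

The expectation is that compound 4 stays close to compound 3 in this assay, with a step from compound 3 to compound 4 of about a 1.1-fold higher number from compound 3 to compound 4 (0.02 log units; within the scatter), which is within the usual scatter. The estimate for compound 4 is 40000 nM, expected to fall between 15000 nM and 100000 nM.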

Compound 4, half-maximal cytotoxic concentration: 26000 nM
Compound 4: the middle estimate sits 1.5-fold (0.19 log units) above what was measured; the measured number falls inside the stated range.
By their numbers in this assay, from the lowest: compound 1; then compounds 4 and 3 (each within the scatter of the next); then compound 2.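

In this assay, putting 4-methylphenyl in place of 2-methylphenyl on the carbonyl carbon gives a 1.5-fold lower number from compound 3 to compound 4 (0.16 log units; within the scatter). Among these compounds, this pair is the first to differ in one place only, so it offers the first direct reading of this position. In this assay, the two places on the ring attached to the carbonyl cannot be told apart for a methyl group, since the step stays within the usual scatter of repeated measurements. With a step this small there is little to explain, and nothing measured here offers any explanation for it.

The compounds shown leave open whether this tolerance of the shift holds only for a small carbon group such as methyl, or also for a different kind of group at this position, such as an amine, a carboxylic acid or a longer chain. They also leave open how a plain phenyl on the carbonyl carbon, with no methyl on either ring of the shared core, would compare with compound 3 and compound 4 in this assay.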